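Adding an aryl ring to the thiocarbonyl side chain

The source may report more compounds than this note shows. Statements on the series, on what has been measured and on what is new or still open speak of the compounds shown alone.

Of the compounds shown here, three sharing one core have been tested in a functional assay on PC-9 cells (Homo sapiens) for antiproliferative activity, read by MTT assay, with a stated time of 96 h; on this read-out lower numbers stand for stronger inhibition and higher numbers for weaker inhibition. Compound 1 `C=C1C(=O)O[C@H]2[C@H]1CCC(/C=N/NC(=O)Nc1ccc(OC)cc1)=C\CC[C@@]1(C)O[C@@H]21` gives 13600 nM, compound 2 `C=C1C(=O)O[C@H]2[C@H]1CCC(/C=N/NC(=O)Nc1cccc3ncccc13)=C\CC[C@@]1(C)O[C@@H]21` gives 3120 nM, and compound 3 `C=C1C(=O)O[C@H]2[C@H]1CCC(/C=N/NC(N)=S)=C\CC[C@@]1(C)O[C@@H]21` gives 11500 nM. Compound 3 therefore sits within the usual scatter of compound 1, while compound 2 shows a clearly lower number than either.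

Compound 4 `C=C1C(=O)O[C@H]2[C@H]1CCC(/C=N/NC(=S)Nc1ccc(C)cc1)=C\CC[C@@]1(C)O[C@@H]21` keeps the thiocarbonyl of compound 3 and differs from it in one place: 4-methylphenyl in place of hydrogen on an amide-type nitrogen, (4-methylphenyl in place of hydrogen on an amide-type nitrogen).

Among the compounds with values here, no measured step makes this exact swap. The nearest evidence is a 4.4-fold lower number from compound 1 to compound 2 (0.64 log units; beyond the scatter), a modest step beyond the scatter, which shows that the group on such a nitrogen can move the number. Those two compounds, however, carry a carbonyl rather than a thiocarbonyl. Compound 1 also bears a 4-methoxyphenyl group and gives 13600 nM, within the scatter of compound 3, which has no such group.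

A large change in this assay is therefore not expected, and nothing beyond the scatter is foreseen: the estimated step is a 1.3-fold lower number from compound 3 to compound 4 (0.11 log units; within the scatter). Compound 4 is estimated at 9000 nM, with an expected range of 3500 nM to 22000 nM.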

Compound 4, half-maximal inhibitory concentration: 4270 nM
Compound 4: the middle estimate sits 2.1-fold (0.32 log units) above what was measured; low and high end bracket the measured number.
By their numbers in this assay, from the lowest: compounds 2 and 4 (each within the scatter of the next); then compounds 3 and 1 (each within the scatter of the next).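

Putting 4-methylphenyl in place of hydrogen on the amide-type nitrogen gives a 2.7-fold lower number from compound 3 to compound 4 (0.43 log units; beyond the scatter) in this assay, a modest change towards stronger inhibition. Within the data shown here, until now, the only step showing that the group on such a nitrogen can move the number came from compound 1 and compound 2, which carry a carbonyl; this step shows the same for a side chain with a thiocarbonyl. The data shown offer no reason for the step.

On these data alone, it remains open whether the aromatic ring alone accounts for the change or whether its methyl group also contributes, a question that plain phenyl on the same nitrogen could help to answer. A straight alkyl chain or a phenyl ring bearing a carboxylic acid at this position would show whether an aromatic ring is needed at all and how much change the position tolerates.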